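Sulfanyl in Place of Aminomethyl on a Cyanoguanidine Chain

The source may hold more compounds than are shown below. What is called first, only, known or untested is meant among the compounds shown, and "the series" means these compounds.

Of the compounds shown here, three have been tested for antagonist activity in a functional assay on Sf9 cells for antagonist activity at histamine H2 receptor (Homo sapiens), read by scintillation counting and GTPgammaS binding, with a stated time of 90 min; a lower number here means a less potent compound, a higher number a more potent compound, by a factor of ten per unit of this negative logarithm. Compound 1 `CN/C(=N/C#N)NCCCCc1c[nH]c(C)n1` gives < 5, which is a limit of the assay and not a number. Compound 2 `CN/C(=N/C#N)NCCCCc1nc[nH]c1C` likewise gives < 5, again a limit. Compound 3 `N#C/N=C(/NCCCCNc1nc(N)n[nH]1)NCCSc1ccccc1` gives < 5, also a limit. Compound 3 therefore stands where all the values shown stand, namely (the limit of < 5 in this assay, at which 3 of the 3 values shown sit), and the numbers do not separate it from the other two.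

Compound 4 `N#C/N=C(/NCCCSc1nc(N)n[nH]1)NCCSc1ccccc1` has not yet been measured. It differs from compound 3 in one place: (3-amino-1H-1,2,4-triazol-5-yl)sulfanyl in place of ((3-amino-1H-1,2,4-triazol-5-yl)amino)methyl on a saturated chain carbon, three bonds along the chain from an amine nitrogen. Within the data shown here, no measured pair of compounds shows the effect of such a change, so the size of the step cannot be read from the data. With every value shown sitting at the limit, compound 4 is expected to stay near that limit, and the step of a number no lower from compound 3 to compound 4 (the limit leaves the size open) is expected to be small, in no established direction. Compound 4 is estimated to give 5, with a range from 4.3 to 5.8.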

Compound 4, negative logarithm of the antagonist equilibrium constant: < 5
Compound 4: only a limit was reported; the forecaster's own chance of this, stated with the estimate: 65%; the middle value lies on the limit itself.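

Compound 3 and compound 4 both rest on a limit and not on a number, so no step between them can be read, and the whole set stands at one place: the limit of < 5 in this assay, at which 4 of the 4 values shown sit.

The compounds shown leave open what (3-amino-1H-1,2,4-triazol-5-yl)sulfanyl in place of ((3-amino-1H-1,2,4-triazol-5-yl)amino)methyl does to antagonist potency.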